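A few compounds are considered here, and "the series" means these few. Any claim that something is new, unique, unknown or untested is made for them only; others in the source may bear on it.

In a functional assay on SK-OV-3 cells (Homo sapiens) for inhibition, read by colorimetric assay and sulforhodamine B assay, with a stated time of 48 h (on this read-out higher numbers stand for weaker inhibition of growth and lower numbers for stronger inhibition of growth), compound 1 (`CCCCCCCCCCCC[C@@H](O)[C@H]1CC[C@H]([C@H](O)CCCCCCCCCCNC(=O)c2cccs2)O1`) gives 28800 nM, while compound 2 (`CCCCCCCCCCCC[C@@H](O)[C@H]1CC[C@H]([C@H](O)CCCCCCCCCCNC(=O)c2ccco2)O1`) gives 100000 nM, the higher of the two numbers. Compound 3 (`CCCCCCCCCCCC[C@@H](O)[C@H]1CC[C@H]([C@H](O)CCCCCCCCCCNC(=O)c2ccoc2)O1`) has the same atoms as compound 2, joined differently: furan-3-yl in place of furan-2-yl on a carbonyl carbon. For the measured compounds named here, only one measured step bears on this change of group on a carbonyl carbon: a 3.5-fold higher number from compound 1 to compound 2 (0.54 log units; beyond the scatter). Going by the values given here, a step of similar or smaller size is expected, probably towards a lower number, although no furan-3-yl compound has yet been measured. The expected step is a 1.8-fold lower number from compound 2 to compound 3 (0.26 log units; within the scatter). For compound 3 the estimated value is 55000 nM, within an expected range of 22000 nM to 120000 nM.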

Compound 3, concentration for 50% growth inhibition: 100000 nM
Compound 3: middle estimate off by 1.8-fold (0.26 log units), on the low side; the measured number falls inside the stated range.
By their numbers in this assay, from the lowest: compound 1; then compounds 2 and 3 (each within the scatter of the next).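

In this assay, the way the furan ring is joined to the carbonyl carbon makes no visible difference, with no change at the digits printed from compound 2 to compound 3 (within the scatter). Furan-3-yl also keeps the gap to thiophen-2-yl, with a 3.5-fold higher number from compound 1 to compound 3 (0.54 log units; beyond the scatter), so among these three groups, the numbers separate thiophen-2-yl from either furan rather than one furan from the other. No available evidence bears on why the two furans match. Still open, going by these compounds, is whether thiophen-3-yl would match thiophen-2-yl, and how a phenyl or pyridine ring on the same carbonyl carbon would compare with compound 1.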